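From pyridin-2-yl to pyridin-3-yl on a shared core

A few compounds are considered here, and "the series" means these few. Any claim that something is new, unique, unknown or untested is made for them only; others in the source may bear on it.

Compound 1 `O=C1/C(=C/c2ccccc2Cl)CCc2c(O)cccc21` gives 1280 nM in a functional assay on RAW264.7 cells (Mus musculus) for inhibition; on this read-out higher numbers stand for weaker inhibition and lower numbers for stronger inhibition.
Compound 2 `O=C1/C(=C/c2ccccn2)CCc2c(O)cccc21` gives 740 nM in this assay.

Of these two numbers compound 2 carries the smaller one, yet its gap to compound 1 lies within the scatter, so no real difference between the two can be claimed. Compound 3 `O=C1/C(=C/c2cccnc2)CCc2c(O)cccc21` differs from compound 2 by pyridin-3-yl in place of pyridin-2-yl on a double-bonded chain carbon bound to a double-bonded ring carbon. No measured step of this kind exists among the shown compounds, so nothing beyond the scatter is expected in either direction. Compound 3 is therefore estimated at 800 nM, within 300 nM to 2200 nM. The expected step is a 1.1-fold higher number from compound 2 to compound 3 (0.03 log units; within the scatter).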

Compound 3, half-maximal inhibitory concentration: 2950 nM
The estimate for compound 3 lay 3.7-fold (0.57 log units) below the measured number, and the stated range ends below it.
By their numbers in this assay, from the lowest: compounds 2 and 1 (each within the scatter of the next); then compound 3.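

In this assay the exchange of pyridin-2-yl for pyridin-3-yl brings a 4.0-fold higher number from compound 2 to compound 3 (0.60 log units; beyond the scatter) and so weaker inhibition. The two groups have the same atoms, joined differently, so this position responds to how the ring is attached and not only to which atoms it carries. Nothing available explains this difference between the two attachments.

On these data alone, it remains open whether pyridin-4-yl at this position would stand with compound 2 or with compound 3. Also open, as far as these compounds go, is how a phenyl ring carrying an amine or a carboxylic acid would fare there.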